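Cytotoxicity limits and the difluorocyclohexyl exchange

The compounds below may be only part of what the source reports. "The series", "measured", "known", "first", "only" and "open" are said of these compounds alone.

Compound 1 `CC1CC=C(C(=O)N(c2cc(C#CC(C)(C)C)sc2C(=O)O)C(C)C)CC1`: > 20000 nM (a limit)
Compound 2 `CC(C)(C)C#Cc1cc(N(C(=O)[C@H]2CC[C@H](C)CC2)[C@H]2CC[C@@H](Oc3cccnc3)CC2)c(C(=O)O)s1`: > 20000 nM (a limit)

In an ADME assay on MT4 cells (Homo sapiens) for cytotoxicity, with a stated time of 5 days (a higher number here means that more compound is tolerated, a lower number that less compound is tolerated), compound 1 gives > 20000 nM, which is a limit and not a number. Compound 2 gives > 20000 nM, which is also a limit. Compound 1 therefore has no numerical value in this assay, and its standing is shared with compound 2: the limit of > 20000 nM in this assay, at which 2 of the 2 values shown sit.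

Compound 3 `CC(C)N(C(=O)C1CCC(F)(F)CC1)c1cc(C#CC(C)(C)C)sc1C(=O)O` keeps the core of compound 1 but carries 4,4-difluorocyclohexyl in place of 4-methylcyclohex-1-en-1-yl on a carbonyl carbon. Within the data shown here, no measured pair isolates this exchange, so the expectation rests on compound 1 and compound 2 sharing (the limit of > 20000 nM in this assay, at which 2 of the 2 values shown sit). In this assay the expected change is none beyond the scatter, with no direction favoured, and the estimated size is a step that the limit leaves unreadable from compound 1 to compound 3. A limit rather than a number is the likely report for the next measurement. For compound 3 the estimated value is 25000 nM, with an expected range of 12000 nM to 50000 nM.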

Compound 3, half-maximal cytotoxic concentration: > 20000 nM
Compound 3 gave a limit, no number; the forecaster's own chance of this, stated with the estimate: 75%; the middle value is on the limit's open side.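

In this assay compound 3 gives > 20000 nM, which is a limit. No step can be read between compound 1 and compound 3, as both stand only as limits. The compounds shown leave open at what concentration any of them becomes cytotoxic in this assay, and whether 4,4-difluorocyclohexyl in place of 4-methylcyclohex-1-en-1-yl alters that concentration.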